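The source may report more compounds than this note shows. Statements on the series, on what has been measured and on what is new or still open speak of the compounds shown alone.

Measured so far:
Compound 1 `COc1ccc2ncc(-c3nn[nH]n3)cc2c1` gives 10 mg/kg in a functional assay on the whole organism (strain Sprague-Dawley) for inhibition, with Rattus norvegicus as the target; a lower number here means that less compound is needed, a higher number that more compound is needed for the effect.
Compound 2 `COc1ccc2ncc(C(=O)O)cc2c1` gives only a limit, > 5 mg/kg, in this assay.
Compound 3 `FC(F)(F)c1cccc2cc(-c3nn[nH]n3)cnc12` gives only a limit, < 25 mg/kg, in this assay.

The change from compound 1 to compound 2 is carboxy in place of 2H-tetrazol-5-yl on an aromatic carbon. Its step, a step that the limit leaves unreadable from compound 1 to compound 2, cannot be sized because compound 2 sits at the limit of > 5 mg/kg in this assay, at which 1 of the 3 values shown sits. Compound 4 `O=C(O)c1cnc2c(C(F)(F)F)cccc2c1` is not yet measured and differs from compound 3 by carboxy in place of 2H-tetrazol-5-yl on an aromatic carbon, the same change at the same place. How the core of compound 1 differs from the core of compound 3 is not broken down here. For compound 3 only a limit is known, (the limit of < 25 mg/kg in this assay, at which 1 of the 3 values shown sits). With the earlier step unreadable, the step of a number no lower from compound 3 to compound 4 (the limit leaves the size open) is a rough expectation resting on a step that the limit leaves unreadable from compound 1 to compound 2 alone. Compound 4 is therefore estimated near 25 mg/kg, between 5 mg/kg and 100 mg/kg, and may again be reported only as a limit.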

Compound 4, minimum effective dose: 50 mg/kg
Compound 4: middle estimate off by 2.0-fold (0.30 log units), on the low side, and the stated range covers the measured number.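

On the core of compound 3, carboxy in place of 2H-tetrazol-5-yl gives an at least 2.0-fold higher number from compound 3 to compound 4 (0.30 log units; that floor lies within the scatter) in this assay. As far as these compounds go, this floor alone does not establish a real change, and the true size of the step stays open because compound 3 is known only as a limit: the limit of < 25 mg/kg in this assay, at which 1 of the 4 values shown sits. The same change on the core of compound 1 cannot be read, so the data do not show whether it carries from one core to the other, because compound 2 is also known only as a limit: the limit of > 5 mg/kg in this assay, at which 1 of the 4 values shown sits.

The compounds shown leave open how an amide or a nitrile on that aromatic carbon would read in this assay. They also leave open whether the change would have the same size on both cores if exact numbers stood at both ends of each step.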